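The source may hold more compounds than are shown below. What is called first, only, known or untested is meant among the compounds shown, and "the series" means these compounds.

Measured compounds:

Compound 1, `COc1cc(NC(C)CCCN2C(=O)[C@@H](C)N(C(=O)CN)C2(C)C)c2ncccc2c1`: in an ADME assay on a cell-free system (plasma, Homo sapiens) for metabolic stability, with Plasma (Rattus norvegicus) as the target, read by HPLC (a higher number here means that the compound lasts longer, a lower number that the compound disappears faster), compound 1 gives > 3 h, which is a limit of the assay rather than a number.
Compound 2, `COc1cc(NC(C)CCCN2C(=O)[C@@H](C)NC2(C)C)c2ncccc2c1`: compound 2 gives > 3 h, again a limit of the assay.
Compound 3, `COc1cc(NC(C)CCCN2C(=O)CNC2(C)C)c2ncccc2c1`: compound 3 gives > 3 h, also a limit of the assay.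

All three measured compounds sit at the same limit, so no ordering among them can be read. The two cores differ as described in hydrogen in place of methyl on a saturated ring carbon; the step this change made is a step that the two limits leave unreadable from compound 2 to compound 3. The change that leads to compound 1, ((aminomethyl)carbonyl in place of hydrogen on an amine nitrogen in a ring), gave the step that the two limits leave unreadable from compound 2 to compound 1. The same kind of change is now made on the core of compound 3 to reach compound 4, `COc1cc(NC(C)CCCN2C(=O)CN(C(=O)CN)C2(C)C)c2ncccc2c1`, described in (aminomethyl)carbonyl in place of hydrogen on an amine nitrogen in a ring. The surroundings are not identical: in compound 2 the ring nitrogen that takes the new group sits next to the ring atom that bears a methyl group, whereas in compound 3 it sits next to the ring atom that bears two methyl groups, so it is the same kind of change rather than the same change.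

Going by the values given here, because the limit of > 3 h in this assay, at which 3 of the 3 values shown sit, shows every value so far resting at the limit, the measured step gives no size to carry over. The step from compound 3 to compound 4 is therefore expected to be a step that the limit leaves unreadable from compound 3 to compound 4, meaning the compound is expected to reach the limit as well. Compound 4 is estimated at 5 h, with a range from 3 h to 12 h.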

Compound 4, half-life: > 3 h
Compound 4: no number, only a limit; the forecaster's own chance of this, stated with the estimate: 85%; the middle value is on the limit's open side.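

Compound 4 sits at the same limit as compound 1 and compound 3, so no size can be read for the step to compound 4 from either of them: the limit of > 3 h in this assay, at which 4 of the 4 values shown sit. The compounds shown leave open how long each one actually lasts in this assay, and whether adding (aminomethyl)carbonyl or replacing methyl with hydrogen changes the half-life at all.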